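A few compounds are considered here, and "the series" means these few. Any claim that something is new, unique, unknown or untested is made for them only; others in the source may bear on it.

Compound 1 `COc1cc2ncnc(Nc3ccc(F)c(Cl)c3)c2cc1OCCCCn1ccnc1[N+](=O)[O-]`: 2210 nM
Compound 2 `COc1cc2ncnc(Nc3cccc(Br)c3)c2cc1OCCCn1ccnc1[N+](=O)[O-]`: 4480 nM
Compound 3 `C#Cc1cccc(Nc2ncnc3cc(OC)c(OCCCn4ccnc4[N+](=O)[O-])cc23)c1`: 5550 nM

All three numbers come from a functional assay on HT-29 cells (Homo sapiens) for cytotoxicity, read by sulforhodamine B assay, with a stated time of 72 h; on this read-out lower numbers stand for stronger inhibition and higher numbers for weaker inhibition. Compound 3 gives the highest of the three; its nearest neighbour is compound 2, whose number lies within the scatter of it, while compound 1 lies furthest away, beyond the scatter and lower. Compound 4 `C#Cc1cccc(Nc2ncnc3cc(OC)c(OCCCCn4ccnc4[N+](=O)[O-])cc23)c1` has not yet been measured. It differs from compound 3 in one place only: (2-nitro-1H-imidazol-1-yl)methyl in place of 2-nitro-1H-imidazol-1-yl on a saturated chain carbon, three bonds along the chain from an oxygen on an aromatic ring. Among the measured compounds shown here, the single measured step that changes one group, a 1.2-fold higher number from compound 2 to compound 3 (0.09 log units; within the scatter), concerns ethynyl in place of bromo and stays within the scatter; no measured pair changes only the length of the chain. Compound 1, with the longer chain, and compound 2, with the shorter chain, differ in two places at once, so their two values show only that the longer chain together with a different halogen pattern went with a lower number. A step near or within the scatter, if anything towards a lower number, is therefore expected in this assay, namely a 1.4-fold lower number from compound 3 to compound 4 (0.14 log units; within the scatter). Compound 4 is estimated at 4000 nM, with a range from 1500 nM to 10000 nM.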

Compound 4, half-maximal inhibitory concentration: 10100 nM
Compound 4: middle estimate off by 2.5-fold (0.40 log units), on the low side, outside the stated range (above it).
By their numbers in this assay, from the lowest: compound 1; then compounds 2, 3 and 4 (each within the scatter of the next, the first and the last beyond it).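

Among the compounds shown here, this is the first pair that changes only the chain length: in this assay, (2-nitro-1H-imidazol-1-yl)methyl in place of 2-nitro-1H-imidazol-1-yl gives a 1.8-fold higher number from compound 3 to compound 4 (0.26 log units; within the scatter), so on these two compounds the longer chain brings no measurable gain. With that same longer chain on both compounds, 3-ethynylphenyl in place of 3-chloro-4-fluorophenyl on the nitrogen gives a 4.6-fold higher number from compound 1 to compound 4 (0.66 log units; beyond the scatter), which places the clear difference in this set at the aromatic group on that nitrogen rather than at the chain. No measurement here explains why either step has the size it has.

From the compounds shown here alone, whether the chain step would read the same with 3-chloro-4-fluorophenyl on that nitrogen remains open. So does the effect of a still longer chain, or of an amine at the chain end in place of the nitroimidazole.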